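The source may report more compounds than this note shows. Statements on the series, on what has been measured and on what is new or still open speak of the compounds shown alone.

Compound 1 `COc1ccc2nc(C)cc(NCc3cccnc3)c2c1`: 44800 nM
Compound 2 `COc1ccc2nc(C)cc(SCc3ccccc3)c2c1`: 30600 nM

Going by the values given here, in a functional assay on MCF-10A cells (Homo sapiens) for antiproliferative activity, with a stated time of 48 h (on this read-out lower numbers stand for an effect already at smaller amounts and higher numbers for an effect only at larger amounts of compound), the values of compound 1 and compound 2 lie within the usual scatter of each other, so compound 1 stands level with the only other measured compound. Compound 3 `COc1ccc2nc(C)cc(NCc3ccccc3F)c2c1` has 2-fluorophenyl in place of pyridin-3-yl on a saturated chain carbon bound to a nitrogen on an aromatic ring. Among the compounds with values here, no measured pair isolates this change. In this assay, little or no step beyond the scatter is expected, with a slight lean towards a lower number: the expected change is a 1.5-fold lower number from compound 1 to compound 3 (0.17 log units; within the scatter). For compound 3 the estimated value is 30000 nM, within an estimated range of 12000 nM to 70000 nM.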

Compound 3, half-maximal effective concentration: 14000 nM
Compound 3: the middle estimate sits 2.1-fold (0.33 log units) above what was measured; measured number inside the range.
By their numbers in this assay, from the lowest: compound 3; then compounds 2 and 1 (each within the scatter of the next).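

Going by these compounds alone, on the saturated chain carbon bound to a nitrogen on an aromatic ring, 2-fluorophenyl in place of pyridin-3-yl gives a 3.2-fold lower number from compound 1 to compound 3 (0.51 log units; beyond the scatter) in this assay and so provides the first step beyond the scatter. The change removes a ring nitrogen and adds a fluorine together, and this pair cannot separate the two. No measurement available here bears on the reason for the step.

Open, on these data alone, is whether unsubstituted phenyl or 2-chlorophenyl on the same carbon would give a similar number. As far as these compounds go, a longer chain to the aromatic ring also remains untested within these compounds.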